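Fluoro for methyl on the sulfamate ring

This account rests on a few compounds, and the source may have more. Where it says the series, first, only, none or still open, it means among the compounds named here.

Compounds with measured results:
compound 1 `Cc1ccccc1N(C)C(=O)c1ccc(-c2ccc(OS(N)(=O)=O)cc2)o1` gives 15%
compound 2 `Cc1ccccc1N(C)C(=O)c1ccc(-c2ccc(OS(N)(=O)=O)c(Cl)c2)o1` gives 25%
compound 3 `Cc1cc(-c2ccc(C(=O)N(C)c3ccccc3C)o2)ccc1OS(N)(=O)=O` gives "nd" (no result reported)

The three measured compounds share one core and differ only at the ring carrying the sulfamoyloxy group. In an assay on cytosol from placenta for inhibition of 17-beta-hydroxysteroid dehydrogenase type 1 (Homo sapiens), read by HPLC, with a stated time of 10 min, tested at 1 uM, in the presence of a further agent that is not named here (on this read-out higher numbers stand for more inhibition at the one concentration tested (going by the name of the read-out) and lower numbers for less inhibition), compound 1 gives 15% and compound 2 gives 25%. For the measured compounds named here, the one step between them, a number 10 percentage points higher from compound 1 to compound 2 (within the scatter), was a chloro in place of hydrogen on an aromatic carbon, and it stayed within the scatter.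

Compound 3 stands nowhere on the numbers: in this assay compound 3 gives "nd" (no result reported), so there is no single value from which to measure a step.

Compound 4 `Cc1ccccc1N(C)C(=O)c1ccc(-c2ccc(OS(N)(=O)=O)c(F)c2)o1` is to be measured. The change from compound 3 is fluoro in place of methyl on an aromatic carbon, on an aromatic carbon ortho to a sulfamoyloxy group and meta to a large group. Going by the values given here, the only step that bears on this position is the one from compound 1 to compound 2, where a small substituent entering at the same place moved the result by an amount within the scatter. Without a number for compound 3, compound 1 serves as the nearest anchor, and the step to compound 4 is expected to be no larger than the scatter. Compound 4 is therefore expected to give about 20% in this assay, with a range from 5% to 35%.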

Compound 4, a percentage reported as inhibition, at one concentration (the size of the read-out at that concentration, not a potency): 18%
Beside the measured number, compound 4's estimate is 2 percentage points above it; the range from low to high includes it.
By their numbers in this assay, from the lowest: compounds 1, 4 and 2 (each within the scatter of the next).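

With compound 4, the aromatic carbon ortho to a sulfamoyloxy group has now been read with hydrogen, chloro and fluoro in this assay, and the two new comparisons are a number 7 percentage points lower from compound 2 to compound 4 (within the scatter) for fluoro in place of chloro and a number 3 percentage points higher from compound 1 to compound 4 (within the scatter) for fluoro in place of hydrogen. Together with the earlier chloro step, these show that the read-out at the one concentration tested does not separate the three substituents at this place, while the step for fluoro in place of methyl itself cannot be read, as compound 3 has no result. No measurement shown here offers an explanation for these numbers.

From the compounds shown here alone, what remains open is whether a methoxy group, a nitrile or a trifluoromethyl group on this carbon would give a step beyond the scatter in this assay. Also open, going by these compounds, is whether hydrogen, chloro and fluoro at this place would separate at other concentrations, and whether replacing the methyl on the amide nitrogen with the amide hydrogen would change the picture.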